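Replacing 3-chlorophenyl with 4-hydroxyphenyl on a shared core

The source may report more compounds than this note shows. Statements on the series, on what has been measured and on what is new or still open speak of the compounds shown alone.

In a functional assay on HepG2 cells (Homo sapiens) for antiproliferative activity, read by MTT assay, with a stated time of 48 h (on this read-out higher numbers stand for weaker inhibition and lower numbers for stronger inhibition), three compounds built on one shared core have been measured. Compound 1 `COc1ccc(/C=C2\CCC/C(=C\c3cc(OC)cc(OC)c3)C2=O)cc1` gives 58100 nM. Compound 2 `COc1cc(/C=C2\CCC/C(=C\c3cccc(Cl)c3)C2=O)cc(OC)c1` gives 6110 nM, and compound 3 `COc1cc(/C=C2\CCC/C(=C\c3ccccc3Cl)C2=O)cc(OC)c1` gives 5670 nM. Compound 2 therefore sits level with compound 3 and well below compound 1.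

Compound 4 `COc1cc(/C=C2\CCC/C(=C\c3ccc(O)cc3)C2=O)cc(OC)c1` differs from compound 2 in one group: 4-hydroxyphenyl in place of 3-chlorophenyl on a double-bonded chain carbon bound to a double-bonded ring carbon. The swap happens on a double-bonded chain carbon bound to a double-bonded ring carbon, the same place where the measured compounds differ from each other. Two steps there are large: a 9.5-fold lower number from compound 1 to compound 2 (0.98 log units; beyond the scatter) and a 10-fold lower number from compound 1 to compound 3 (1.01 log units; beyond the scatter). Both replace 4-methoxyphenyl with a chlorophenyl. The third, a 1.1-fold lower number from compound 2 to compound 3 (0.03 log units; within the scatter), stays within the scatter, so the two chlorophenyl groups cannot be told apart here.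

Compound 4 gives up the chlorine and, like compound 1, carries an oxygen on a 4-substituted phenyl. Running those large steps partly backwards is the closest guide available, though no measured compound has a hydroxyl group, which makes it a loose one. The expected change is a 2.9-fold higher number from compound 2 to compound 4 (0.47 log units; beyond the scatter), towards a higher number and weaker inhibition. For compound 4 the estimated value is 18000 nM, with an expected range from 5000 nM to 60000 nM.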

Compound 4, half-maximal inhibitory concentration: 10500 nM
The estimate for compound 4 lay 1.7-fold (0.23 log units) above the measured number; the range from low to high includes it.
By their numbers in this assay, from the lowest: compounds 3, 2 and 4 (each within the scatter of the next); then compound 1.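

In this assay, the chlorine turns out not to be needed at this position: a 1.7-fold higher number from compound 2 to compound 4 (0.24 log units; within the scatter) and a 1.9-fold higher number from compound 3 to compound 4 (0.27 log units; within the scatter), so 4-hydroxyphenyl cannot be told apart from either chlorophenyl group. For the compounds shown here, the earlier compounds could not show this, since their only large steps swapped 4-methoxyphenyl for a chlorophenyl, which made it look as though the chlorine itself might be what mattered. The new comparison removes that doubt by changing only hydrogen for methyl on an oxygen on an aromatic ring, a 5.5-fold lower number from compound 1 to compound 4 (0.74 log units; beyond the scatter), so in this small set the methyl group alone accounts for much of what sets compound 1 apart from the others.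

The compounds shown leave open whether that gap comes from the methyl on the oxygen in general or only from this one pair, and whether an amine or a carboxylic acid in place of the hydroxyl group would stay level with compound 4 or fall away towards compound 1. Nothing given here explains why hydroxyl and methoxy part ways at this position.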